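The compounds below may be only part of what the source reports. "The series", "measured", "known", "first", "only" and "open" are said of these compounds alone.

Measured so far in an assay on isolated protein for inhibition of 15-hydroxyprostaglandin dehydrogenase [NAD(+)] (Homo sapiens), read by fluorescence, with a stated time of 15 min; on this read-out lower numbers stand for stronger inhibition and higher numbers for weaker inhibition:
compound 1 `COc1cccc(-n2cnc3cc(C(=O)N4CCCCC4)ccc32)c1` gives 19 nM
compound 2 `Cc1ccc(-n2cnc3cc(C(=O)N4CCCCC4)ccc32)cc1` gives 19 nM
compound 3 `O=C(c1ccc2c(c1)ncn2-c1ccc(C(F)(F)F)cc1)N1CCCCC1` gives 86 nM

Compound 2 sits level with compound 1, the two lowest numbers of the three, with no change at the digits printed from compound 1 to compound 2 (within the scatter) within the scatter; compound 3 lies furthest off, after a 4.5-fold higher number from compound 2 to compound 3 (0.66 log units; beyond the scatter).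

Compound 4 `CC(C)(C)n1cnc2cc(C(=O)N3CCCCC3)ccc21` is the next to be measured. Against compound 2 the change is tert-butyl in place of 4-methylphenyl on an aromatic nitrogen. Going by the values given here, no measured step swaps the whole aryl group for an alkyl; the two known steps only vary substituents on that ring, one without effect and one a modest loss. The change here is larger than either, so a step of uncertain direction, probably toward weaker inhibition, is expected: a 3.2-fold higher number from compound 2 to compound 4 (0.50 log units; beyond the scatter). For compound 4 the estimate is 60 nM, within 15 nM to 250 nM.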

Compound 4, half-maximal inhibitory concentration: 34 nM
Compound 4: middle estimate off by 1.8-fold (0.25 log units), on the high side, within the range that was stated.
By their numbers in this assay, from the lowest: compounds 1, 2 and 4 (each within the scatter of the next); then compound 3.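

In this assay, the aromatic nitrogen does not depend on an aryl group: tert-butyl, which has no ring, stays within the scatter of both aryl compounds (a 1.8-fold higher number from compound 2 to compound 4 (0.25 log units; within the scatter) and a 1.8-fold higher number from compound 1 to compound 4 (0.25 log units; within the scatter)). This position therefore accepts a branched alkyl group in place of either 4-methylphenyl or 3-methoxyphenyl. Nothing available explains this tolerance. Still open, from the compounds shown here alone, is how a cyclohexyl group or a longer chain ending in an amine would behave on that nitrogen. The piperidine amide is also unchanged throughout, so its contribution cannot be judged.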